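Methylsulfonyl for Sulfamoyl on a Shared Aminothiazole Core

The source may hold more compounds than are shown below. What is called first, only, known or untested is meant among the compounds shown, and "the series" means these compounds.

Measured so far:
Compound 1 `CS(=O)(=O)c1ccc(Nc2ncc(F)c(Nc3nc4ccc(Cl)cc4s3)n2)cc1` — in a functional assay on PC-3 cells (Homo sapiens) for antiproliferative activity, read by MTT assay, with a stated time of 48 h (on this read-out lower numbers stand for stronger inhibition and higher numbers for weaker inhibition), compound 1 gives > 50000 nM, a limit of the assay.
Compound 2 `COc1ccc2nc(Nc3nc(Nc4ccc(S(N)(=O)=O)cc4)ncc3F)sc2c1` — in this assay compound 2 gives > 50000 nM, likewise a limit and not a number.

Among the compounds with values here, compound 2 therefore stands at the edge of what this assay can report: it has no measured number, only a limit, and the one other value shown is a limit as well (the limit of > 50000 nM in this assay, at which 2 of the 2 values shown sit).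

Compound 3 `COc1ccc2nc(Nc3nc(Nc4ccc(S(C)(=O)=O)cc4)ncc3F)sc2c1` keeps the core of compound 2 and differs in one place, (methyl in place of amino on a sulfonyl sulfur); read one bond further out, this is sulfamoyl to methylsulfonyl. Compound 1 already carries the methylsulfonyl group on a related core and sits at the same limit, so no step beyond the usual scatter is expected in this assay.

For compound 3 the estimate in this assay is 60000 nM, with a range from 20000 nM to 200000 nM. The expected step that the limit leaves unreadable from compound 2 to compound 3 is essentially none, and compound 3 is most likely to be reported again as a limit.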

Compound 3, half-maximal inhibitory concentration: 1270 nM
For compound 3 the middle estimate is 47-fold (1.67 log units) above the measured one, outside the stated range (below it).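

In this assay, methyl in place of amino on a sulfonyl sulfur turns a limit into a measurable value on the core of compound 2, with an at least 39-fold lower number from compound 2 to compound 3 (1.59 log units; beyond the scatter). The methylsulfonyl group alone does not account for this, for methoxy in place of chloro on an aromatic carbon, with that group kept, gives an at least 39-fold lower number from compound 1 to compound 3 (1.59 log units; beyond the scatter). Both steps are only bounds, because each starts from a limit and not from a number: the limit of > 50000 nM in this assay, at which 2 of the 3 values shown sit.

The compounds shown leave open whether the sulfonyl sulfur tolerates anything larger than methyl, such as an ethyl group or a dimethylamino group. They also leave open whether an ethoxy group or a fluoro group on that aromatic carbon would serve as methoxy does.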